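A Side-Chain Swap at the Limit of the Assay

The source may report more compounds than this note shows. Statements on the series, on what has been measured and on what is new or still open speak of the compounds shown alone.

In an ADME assay on CCRF-CEM cells (Homo sapiens) for cytotoxicity, with a stated time of 5 days (on this read-out lower numbers stand for stronger inhibition and higher numbers for weaker inhibition), compound 2 (`[N-]=[N+]=N[C@H]1C[C@H](n2cnc3c(NC4CC4)nc(N)nc32)O[C@@H]1CO`) gives > 100000 nM and this is a limit, not a number. Compound 1 (`CC(C)(CO)Nc1nc(N)nc2c1ncn2[C@H]1C[C@H](N=[N+]=[N-])[C@@H](CO)O1`) gives > 100000 nM and this too is a limit. Compound 2 therefore has no exact value to start from.

Compound 3 (`CC(CO)Nc1nc(N)nc2c1ncn2[C@H]1C[C@H](N=[N+]=[N-])[C@@H](CO)O1`) changes compound 2 in one place, with 1-(hydroxymethyl)ethyl in place of cyclopropyl on a nitrogen on an aromatic ring is the full count of that change.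

For the measured compounds named here, only one measured step bears on this, a step that the two limits leave unreadable from compound 1 to compound 2 and it swaps cyclopropyl for 1-(hydroxymethyl)-1-methylethyl in the opposite direction. Its size cannot be read, since the evidence so far is the limit of > 100000 nM in this assay, at which 2 of the 2 values shown sit, and neither end is a number. Going by the values given here, the entering group has a name close to the one carried by compound 1, which reads > 100000 nM in this assay and gives no sign of stronger inhibition. No step beyond the scatter is therefore expected. The expected change is a number no higher from compound 2 to compound 3 (the limit leaves the size open) and it remains an estimate. For compound 3 the estimated value is 100000 nM with an expected range from 40000 nM to 200000 nM and the assay will most likely report only a limit.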

Compound 3, half-maximal inhibitory concentration: > 100000 nM
Compound 3: only a limit was reported; the forecaster's own chance of this, stated with the estimate: 85%; the middle value lies on the limit itself.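

For the compounds shown here, compound 1, compound 2 and compound 3 each give only a limit in this assay, not a number, so no step among them can be read: the limit of > 100000 nM in this assay, at which 3 of the 3 values shown sit. The compounds shown leave open what exact value any of the three has, and whether changing the group on the nitrogen shifts that value at all.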